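This account rests on a few compounds, and the source may have more. Where it says the series, first, only, none or still open, it means among the compounds named here.

Of the compounds shown here, two have solubility numbers so far. Compound 1 `Fc1ccc(Cc2ccc3c(NCCCNCc4ccco4)ccnc3c2)c(Cl)c1` in a physicochemical assay for solubility, with a stated time of 18 h, at pH 7.4 (on this read-out higher numbers stand for higher solubility and lower numbers for lower solubility), gives 4200 nM. Compound 2 `COc1cccc(CNCCCNc2ccnc3cc(Oc4ccccc4)ccc23)c1O` in this assay gives 14500 nM, the higher of the two numbers, and its gap to compound 1 lies beyond the scatter. The two do not differ in a single place, so the comparison shows only what the two values are.

Compound 3 `COc1cccc(CNCCCNc2ccnc3cc(Cc4ccc(F)cc4Cl)ccc23)c1O` is not yet measured. It differs from compound 2 in one place: 2-chloro-4-fluorobenzyl in place of phenoxy on an aromatic carbon. Going by the values given here, the group that enters is the one carried by compound 1; the rest of compound 3 stays as in compound 2.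

Among the compounds with values here, no measured step isolates this change, so the expectation rests on the two values alone. The solubility of compound 3 is expected to fall from compound 2 toward compound 1, because compound 1 carrying the same entering group gives 4200 nM in this assay. The expected step from compound 2 to compound 3 is a 2.4-fold lower number from compound 2 to compound 3 (0.38 log units; beyond the scatter), a decrease beyond the scatter. For compound 3 in this assay the estimate is 6000 nM, with a range from 2500 nM to 15000 nM.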

Compound 3, solubility: 4200 nM
Compound 3: the middle estimate sits 1.4-fold (0.15 log units) above what was measured; low and high end bracket the measured number.
By their numbers in this assay, from the lowest: compounds 1 and 3 (each within the scatter of the next); then compound 2.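

On the aromatic carbon that is meta to a fused ring and para to a fused ring, 2-chloro-4-fluorobenzyl in place of phenoxy now has a reading of its own in this assay, with a 3.5-fold lower number from compound 2 to compound 3 (0.54 log units; beyond the scatter); compounds 1 and 2 differ in more than one place and could not give this. With 2-chloro-4-fluorobenzyl held fixed, 2-hydroxy-3-methoxyphenyl in place of furan-2-yl on a saturated chain carbon bound to an amine nitrogen gives no change at the digits printed from compound 1 to compound 3 (within the scatter), so among these three compounds only the change on the aromatic carbon gives a step beyond the scatter. Nothing at hand speaks to the reason for either step.

Going by these compounds, the chain change has been read only with 2-chloro-4-fluorobenzyl on the aromatic carbon, and the aromatic change only with 2-hydroxy-3-methoxyphenyl on the chain, so whether either step carries over to the other partner group stays open. On these data alone, only phenoxy and 2-chloro-4-fluorobenzyl appear at this aromatic carbon, so the readings for an unsubstituted benzyl or an amine there also stay open.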